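The source may hold more compounds than are shown below. What is called first, only, known or untested is meant among the compounds shown, and "the series" means these compounds.

Compound 2 `CCOC(=O)CCCCCOc1cccc(CN(C(=O)c2ccc(-c3cccc(-c4ccccc4)c3)cc2)C(C)C)c1` carries a 3-phenylphenyl group where compound 1 `CCOC(=O)CCCCCOc1cccc(CN(C(=O)c2ccc(-c3ccncc3)cc2)C(C)C)c1` carries pyridin-4-yl. In an ADME assay on HepG2 cells (Homo sapiens) for cytotoxicity, read by CellTiter-Glo and resazurin assay, with a stated time of 72 h (a lower number here means that less compound is needed, a higher number that more compound is needed for the effect), compound 1 gives > 26000 nM, which is a limit of the assay rather than a number. In this assay compound 2 gives > 26000 nM, likewise a limit. The step that the two limits leave unreadable from compound 1 to compound 2 therefore cannot be read, because both values rest at the limit of > 26000 nM in this assay, at which 2 of the 2 values shown sit. Compound 2 thus stands at that limit, alongside compound 1, and neither can be placed above or below the other on the numbers shown.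

Compound 3 `CCOC(=O)CCCCCOc1cccc(CN(C(=O)c2ccc(-c3cccc(C(C)=O)c3)cc2)C(C)C)c1` differs from compound 2 in one place: acetyl in place of phenyl on an aromatic carbon. Among the measured compounds shown here, the only measured step bears on this assay but is itself unreadable, so it sets no size or direction for the change from phenyl to acetyl. For the measured compounds named here, the measured values show only that two compounds with quite different groups at the same place both reach the limit. Compound 3 is therefore expected to remain at or near that limit, with an estimated step that the limit leaves unreadable from compound 2 to compound 3. The estimate for compound 3 is 30000 nM, within 10000 nM to 100000 nM, and most likely it is again reported only as a limit.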

Compound 3, half-maximal effective concentration: > 26000 nM
Compound 3: no number, only a limit (the forecaster's own chance of this, stated with the estimate: 75%); the middle value does not contradict the limit.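

In this assay compound 3 gives > 26000 nM as a limit of the assay, not a number. Among the compounds shown here, no step among compound 1, compound 2 and compound 3 can be read, because all three values rest at one limit: the limit of > 26000 nM in this assay, at which 3 of the 3 values shown sit. The compounds shown leave open how far these three differ in this assay and whether any change at this place gives a readable value.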